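The source may report more compounds than this note shows. Statements on the series, on what has been measured and on what is new or still open speak of the compounds shown alone.

Among the compounds with values here, compound 2 `O=C1O[C@H]([C@@H](O)Cn2cc(CNS(=O)(=O)c3ccc(Cl)cc3)nn2)C(OCc2ccccc2)=C1OCc1ccccc1` gives the lowest of the two numbers known so far in an ADME assay on HFF cells (Homo sapiens) for cytotoxicity, read by MTT assay, with a stated time of 72 h; on this read-out lower numbers stand for stronger inhibition and higher numbers for weaker inhibition: compound 2 gives 20 nM, and its only neighbour, compound 1 `O=C1O[C@H]([C@@H](O)Cn2cc(-c3cccc(O)c3)nn2)C(OCc2ccccc2)=C1OCc1ccccc1`, gives 39000 nM. Those two compounds differ in one place, and the step of a 2000-fold lower number from compound 1 to compound 2 (3.29 log units; beyond the scatter) was large. Compound 3 `CCCCCCCCCCc1cn(C[C@H](O)[C@H]2OC(=O)C(OCc3ccccc3)=C2OCc2ccccc2)nn1` has not been measured yet. It differs from compound 2 by nonyl in place of ((4-chlorophenyl)sulfonyl)amino on a saturated chain carbon bound to an aromatic carbon. Within the data shown here, the only measured step that bears on it is that from compound 1 to compound 2, and it exchanges a different group than the one now leaving, so it fixes the direction and size of the present step only loosely. It does show that the group at this position can move this read-out by a large amount, so the replacement of the sulfonamide-bearing group by a plain nonyl chain is expected to carry a substantial step, and a loss of part of the effect seen in compound 2 is the more likely direction. The author therefore expects for compound 3 a step of a 100-fold higher number from compound 2 to compound 3 (2.00 log units; beyond the scatter), giving an estimated value of 2000 nM, within a range from 200 nM to 20000 nM.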

Compound 3, half-maximal inhibitory concentration: > 100000 nM
Compound 3 was reported as a limit (the forecaster's own chance of this, stated with the estimate: 5%); middle value at least 50-fold (1.69 log units) away from the limit.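

In this assay compound 3 is reported only as a limit, > 100000 nM. Replacing ((4-chlorophenyl)sulfonyl)amino with nonyl on a saturated chain carbon bound to an aromatic carbon gives an at least 5000-fold higher number from compound 2 to compound 3 (3.69 log units; beyond the scatter), so the low number of compound 2 does not persist when a plain chain stands at this position on the shared core. Exchanging 3-hydroxyphenyl for decyl on an aromatic carbon gives an at least 2.5-fold higher number from compound 1 to compound 3 (0.40 log units; beyond the scatter), which shows that a ring is not required for a high number here, and both compounds without the sulfonamide-bearing group lie far from compound 2.

Both steps are lower bounds, and their true sizes cannot be read from a limit. The compounds shown also leave open whether the low number of compound 2 depends on the sulfonyl amino link or on the 4-chlorophenyl ring, a question that a carboxamide link or an unsubstituted phenyl ring at the same place could separate.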